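The source may report more compounds than this note shows. Statements on the series, on what has been measured and on what is new or still open speak of the compounds shown alone.

In a functional assay on MDA-MB-435 cells (Homo sapiens) for cytotoxicity, read by MTT assay, with a stated time of 72 h (on this read-out lower numbers stand for stronger inhibition and higher numbers for weaker inhibition), compound 1 `CN(C)CCCNc1c(C(=O)NCc2ccc(F)cc2)nc(Br)c2cccnc12` gives 7000 nM and compound 2 `CN(C)c1ccc(CNC(=O)c2nc(Br)c3cccnc3c2N[C@H]2CC[C@H](N)CC2)cc1` gives 4000 nM, two values within the usual scatter of each other. Compound 3 `NCCCNc1c(C(=O)NCc2ccc(F)cc2)ncc2cccnc12` gives 16000 nM, a higher number than compound 2 by more than that scatter. Compound 4 `N[C@H]1CC[C@H](Nc2c(C(=O)NCc3ccccc3)nc(Br)c3cccnc23)CC1` has not yet been measured. It differs from compound 2 in one place: hydrogen in place of dimethylamino on an aromatic carbon, with hydrogen in place of dimethylamino on an aromatic carbon, para to a large group. Within the data shown here, no measured pair shows this change alone, so the expectation is only a modest one, with no shift beyond the scatter. The expected move is small, a 1.3-fold higher number from compound 2 to compound 4 (0.10 log units; within the scatter). For compound 4 the estimated value is 5000 nM, with an expected range from 2000 nM to 12000 nM.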

Compound 4, half-maximal inhibitory concentration: 7000 nM
For compound 4 the middle estimate is 1.4-fold (0.15 log units) below the measured one, and the stated range covers the measured number.
By their numbers in this assay, from the lowest: compounds 2, 1 and 4 (each within the scatter of the next); then compound 3.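

In this assay, the change from 4-(dimethylamino)benzyl to benzyl gives a 1.8-fold higher number from compound 2 to compound 4 (0.24 log units; within the scatter), so this assay does not tell these two groups apart. Among these compounds, this is the first direct comparison of a single change, and it shows that dimethylamino, on an aromatic carbon para to a large group, can give way to hydrogen without a shift beyond the scatter. No supporting measurement explains this result. Still open, on these data alone, is whether a methoxy group or a carboxylic acid at this place would read differently from hydrogen.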